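The source may report more compounds than this note shows. Statements on the series, on what has been measured and on what is new or still open speak of the compounds shown alone.

Compound 1 `COc1ccc(-c2c[nH]c(=O)n2-c2cc(OC)c(OC)c(OC)c2)cc1N`: 49200 nM
Compound 2 `COc1cc(-n2c(-c3ccccc3)cn(C(C)=O)c2=O)cc(OC)c1OC`: > 50000 nM (a limit)
Compound 3 `COc1cc(-n2c(-c3ccc(F)cc3F)cn(C(C)=O)c2=O)cc(OC)c1OC`: > 50000 nM (a limit)

All three were tested in a functional assay on K562 cells (Homo sapiens) for cytotoxicity, read by MTT assay, with a stated time of 48 h; on this read-out higher numbers stand for weaker inhibition and lower numbers for stronger inhibition. Compound 3 stands at the limit of > 50000 nM in this assay, at which 2 of the 3 values shown sit, so it has a limit and no exact number. Going by the values given here, the only measured step, a step that the two limits leave unreadable from compound 2 to compound 3, offers no size to carry forward.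

Compound 4 `COc1ccc(-c2cn(C(C)=O)c(=O)n2-c2cc(OC)c(OC)c(OC)c2)cc1N` brings a new change: 3-amino-4-methoxyphenyl in place of 2,4-difluorophenyl on an aromatic carbon. Compound 1 carries the same 3-amino-4-methoxyphenyl group without the acetyl group and gives 49200 nM, which is weak but measurable. A similarly weak result, perhaps slightly stronger than the limit, is therefore expected in this assay, and another limit would be no surprise. The expected change is an at least 2.0-fold lower number from compound 3 to compound 4 (0.30 log units; that floor lies within the scatter). For compound 4, the estimate is 25000 nM, with an expected range of 3000 nM to 50000 nM.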

Compound 4, half-maximal inhibitory concentration: 500 nM
Compound 4: middle estimate off by 50-fold (1.70 log units), on the high side; measured number outside the range, below it.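

In this assay, 3-amino-4-methoxyphenyl on this aromatic carbon gives an at least 100-fold lower number from compound 3 to compound 4 (2.00 log units; beyond the scatter), and an at least 100-fold lower number from compound 2 to compound 4 (2.00 log units; beyond the scatter). Acetyl in place of hydrogen on the aromatic nitrogen gives a 98-fold lower number from compound 1 to compound 4 (1.99 log units; beyond the scatter), so among these compounds only compound 4, which carries both groups, reaches strong inhibition. Compound 2 and compound 3, with acetyl but other aromatic groups, each give only a limit: the limit of > 50000 nM in this assay, at which 2 of the 4 values shown sit.

On these data alone, it remains open whether the amine or the methoxy group of the new ring is needed for this gain. Also open, as far as these compounds go, is whether a longer acyl chain, such as propionyl, would serve in place of acetyl.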